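Methylsulfanyl to methylcarbamoyl on two oxazole cores

The source may report more compounds than this note shows. Statements on the series, on what has been measured and on what is new or still open speak of the compounds shown alone.

Compound 1 `CSc1coc(C(=O)CCCCCCc2ccccc2)n1` carries a methylsulfanyl group on its aromatic ring. In an assay on HEK-293T cells for inhibition of diacylglycerol lipase-alpha (Homo sapiens), read by colorimetric assay (a lower number here means a stronger inhibitor, a higher number a weaker inhibitor), compound 1 gives only a limit, > 10000 nM. Compound 2 `CNC(=O)c1coc(C(=O)CCCCCCc2ccccc2)n1` differs by methylcarbamoyl in place of methylsulfanyl on an aromatic carbon. In this assay compound 2 likewise gives only a limit, > 10000 nM. The step that the two limits leave unreadable from compound 1 to compound 2 therefore cannot be sized. Compound 3 `CSc1cnc(C(=O)CCCCCCc2ccccc2)o1` is built from the same atoms as compound 1, joined differently, the difference being (5-(methylsulfanyl)-1,3-oxazol-2-yl in place of 4-(methylsulfanyl)-1,3-oxazol-2-yl on a carbonyl carbon). In this assay compound 3 also gives only a limit, > 10000 nM. The step that the two limits leave unreadable from compound 1 to compound 3 is unreadable as well, because of the limit of > 10000 nM in this assay, at which 3 of the 3 values shown sit.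

Compound 4 `CNC(=O)c1cnc(C(=O)CCCCCCc2ccccc2)o1` is not yet measured; it differs from compound 3 by methylcarbamoyl in place of methylsulfanyl on an aromatic carbon. This is the same kind of change as from compound 1 to compound 2, but the place differs: in compound 4 the group sits next to the ring oxygen and two ring bonds from the ring nitrogen, whereas in compound 2 it sits next to the ring nitrogen and two ring bonds from the ring oxygen. Within the data shown here, since every value so far is a limit, the step that the limit leaves unreadable from compound 3 to compound 4 is expected to be small and compound 4 is estimated at 20000 nM, most likely again reported as a limit, with a range of 8000 nM to 100000 nM.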

Compound 4, half-maximal inhibitory concentration: > 10000 nM
Compound 4 ended at the assay's limit; the forecaster's own chance of this, stated with the estimate: 85%; the middle value is on the limit's open side.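

Compound 3 and compound 4 each give only a limit in this assay, so no size can be read for the step between them, because every value sits at the same limit: the limit of > 10000 nM in this assay, at which 4 of the 4 values shown sit.

The compounds shown leave open how strongly any of the four inhibits in this assay, and whether methylcarbamoyl in place of methylsulfanyl changes that strength on either core.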